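Benzoxazole sulfonamides at the assay limit

The source may hold more compounds than are shown below. What is called first, only, known or untested is meant among the compounds shown, and "the series" means these compounds.

Measured so far in an assay on isolated protein for inhibition of malate dehydrogenase, mitochondrial (Sus scrofa), with stated times of 45 min and 30 min; on this read-out higher numbers stand for weaker inhibition and lower numbers for stronger inhibition:
Compound 1 `O=S(=O)(Nc1ccc(-c2nc3ccccc3o2)cc1)c1cccc(Cl)c1` gives > 63000 nM, which is a limit of the assay and not a number.
Compound 2 `Cc1cccc(S(=O)(=O)Nc2ccc3oc(-c4ccccc4)nc3c2)c1` gives > 63000 nM, likewise a limit.
Compound 3 `O=S(=O)(Nc1ccc(-c2nc3ccccc3o2)cc1)c1cccc(C(F)(F)F)c1` gives > 63000 nM, likewise a limit.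

Compound 1 therefore stands only at a limit, and every value shown sits at that same limit (the limit of > 63000 nM in this assay, at which 3 of the 3 values shown sit). Among the compounds with values here, the single step between measured compounds that differ in one place, a step that the two limits leave unreadable from compound 1 to compound 3, trifluoromethyl in place of chloro on an aromatic carbon, cannot be read because both of its ends are limits.

Compound 4 `O=S(=O)(Nc1ccc(-c2nc3ccccc3o2)cc1)c1ccccc1F` differs from compound 1 by 2-fluorophenyl in place of 3-chlorophenyl on a sulfonyl sulfur. Within the data shown here, no measured step touches this change directly, and the one step on record gives no size, so no direction can be drawn from the series; the working assumption is that compound 4 stays where the rest of the series sits. Compound 4 is thus expected at 100000 nM, within 30000 nM to 400000 nM. The step that the limit leaves unreadable from compound 1 to compound 4 is expected to lie within the scatter, with a further limit the most probable outcome.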

Compound 4, half-maximal inhibitory concentration: > 63000 nM
Compound 4 gave a limit, no number; the forecaster's own chance of this, stated with the estimate: 85%; the middle value is on the limit's open side.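

Compound 1 and compound 4 both stand at a limit, not a number, so no step can be read between them, and the series offers no other reading: the limit of > 63000 nM in this assay, at which 4 of the 4 values shown sit.

The compounds shown leave open whether any close relative of this series gives a measurable number.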